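Swapping one bicyclic amine for another on the thiocarbonyl carbon

A few compounds are considered here, and "the series" means these few. Any claim that something is new, unique, unknown or untested is made for them only; others in the source may bear on it.

Compound 1, `COc1ccc(CN(C(=O)CSC(=S)N2CCN(C(C)=O)CC2)c2cc(OC)c(OC)c(OC)c2)cc1`, in a functional assay on HCT-116 cells (Homo sapiens) for inhibition, read by CCK-8 assay, with a stated time of 48 h (on this read-out lower numbers stand for stronger inhibition and higher numbers for weaker inhibition), gives 1370 nM.
Compound 2, `COc1ccc(CN(C(=O)CSC(=S)N2CCc3ccccc32)c2cc(OC)c(OC)c(OC)c2)cc1`, in this assay gives 7710 nM.

Of the two measured compounds, compound 2 has the higher number, separated from compound 1 by a 5.6-fold higher number from compound 1 to compound 2 (0.75 log units; beyond the scatter). Compound 3, `COc1ccc(CN(C(=O)CSC(=S)N2CCCc3cc(C)ccc32)c2cc(OC)c(OC)c(OC)c2)cc1`, is not yet measured. It differs from compound 2 in one place: 6-methyl-1,2,3,4-tetrahydroquinolin-1-yl in place of 2,3-dihydro-1H-indol-1-yl on a thiocarbonyl carbon. Among the compounds with values here, the only measured step replaced 4-acetylpiperazin-1-yl with 2,3-dihydro-1H-indol-1-yl on the same thiocarbonyl carbon, and that step was modest. Within the data shown here, no measured pair shows what exchanging one ring-fused amine for another does here, so the step from compound 2 to compound 3 has no direct precedent. Compound 3 is therefore expected to land close to compound 2, with a 1.1-fold lower number from compound 2 to compound 3 (0.04 log units; within the scatter) likely within the scatter and with no direction favoured. The estimated value of compound 3 in this assay is 7000 nM, with a range from 2500 nM to 20000 nM.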

Compound 3, half-maximal inhibitory concentration: 5230 nM
Estimate against measurement, compound 3: 1.3-fold (0.13 log units) above; the range from low to high includes it.
By their numbers in this assay, from the lowest: compound 1; then compounds 3 and 2 (each within the scatter of the next).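

In this assay, replacing the 2,3-dihydro-1H-indol-1-yl on the thiocarbonyl carbon with 6-methyl-1,2,3,4-tetrahydroquinolin-1-yl gives a 1.5-fold lower number from compound 2 to compound 3 (0.17 log units; within the scatter), so a change that enlarges the non-aromatic ring from five-membered to six-membered and adds a methyl group does not separate these two compounds. The second ring-fused amine also falls short of the 4-acetylpiperazin-1-yl, with a 3.8-fold higher number from compound 1 to compound 3 (0.58 log units; beyond the scatter), which means that the advantage of compound 1 now holds against both ring-fused amines shown. The data offer no explanation for either result.

The ring size and the methyl group change together here, so the contribution of each cannot be read separately. Also open, going by these compounds, is how a plain piperidine, a morpholine, or a piperazine carrying an acyl group other than acetyl would behave on this carbon.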